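This account rests on a few compounds, and the source may have more. Where it says the series, first, only, none or still open, it means among the compounds named here.

In a physicochemical assay for solubility, at pH 7.4 (a lower number here means a less soluble compound, a higher number a more soluble compound), compound 1 (`Cc1c2c(n3c1CCN(C(=O)CN)C[C@@H](C)[C@H](C)Nc1cc-3ccc1C(N)=O)CC(C)(C)CC2=O`) gives 46 ug/mL. Compound 2 (`CC[C@H](N)C(=O)N1CCc2c(C)c3c(n2-c2ccc(C(N)=O)c(c2)N[C@@H](C)[C@H](C)C1)CC(C)(C)CC3=O`) gives > 100 ug/mL, which is a limit of the assay and not a number. On these data alone, compound 2 thus stands at the limit of > 100 ug/mL in this assay, at which 1 of the 2 values shown sits, and its true value remains open. Compound 3 (`Cc1c2c(n3c1CCN(C(=O)[C@@H](N)C(C)C)C[C@@H](C)[C@H](C)Nc1cc-3ccc1C(N)=O)CC(C)(C)CC2=O`) differs from compound 2 by one change: methyl in place of hydrogen on a saturated chain carbon bound to two saturated chain carbons, in words methyl in place of hydrogen on a saturated chain carbon bound to two saturated chain carbons. For the measured compounds named here, one measured step bears on this, an at least 2.1-fold higher number from compound 1 to compound 2 (0.33 log units; beyond the scatter), where ethyl takes the place of hydrogen on a saturated chain carbon bound to an amine nitrogen and a carbonyl carbon. That single step is a thin basis and has no exact size, so no step beyond the scatter is expected in this assay. The expected step is a number no higher from compound 2 to compound 3 (the limit leaves the size open). Compound 3 is estimated at 100 ug/mL, with an expected range of 50 ug/mL to 200 ug/mL.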

Compound 3, solubility: > 100 ug/mL
Compound 3: no number, only a limit; the forecaster's own chance of this, stated with the estimate: 60%; the middle value lies on the limit itself.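

In this assay compound 3 gives > 100 ug/mL, which is a limit of the assay and not a number. Isopropyl in place of hydrogen on the saturated chain carbon bound to an amine nitrogen and a carbonyl carbon gives an at least 2.1-fold higher number from compound 1 to compound 3 (0.33 log units; beyond the scatter), so the rise seen with ethyl at this place also holds for isopropyl. The added methyl on a saturated chain carbon bound to two saturated chain carbons cannot be read, since the step between the two compounds that carry limits has no size: the limit of > 100 ug/mL in this assay, at which 2 of the 3 values shown sit.

On these data alone, the true order of compound 2 and compound 3, and the full size of their rise from compound 1, remain open. Also open, as far as these compounds go, is how a phenyl group or a carboxylic acid on that same carbon would read in this assay.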